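The compounds below may be only part of what the source reports. "The series", "measured", "known", "first", "only" and "open" are said of these compounds alone.

For the measured compounds named here, compound 1 `C[C@H](NC(=O)C(=O)Nc1ccccc1F)C(=O)N[C@@H](CC(=O)O)C(=O)COc1c(F)c(F)cc(F)c1F` gives 160 nM in a functional assay on Jurkat cells (Homo sapiens) for inhibition (a lower number here means a stronger inhibitor, a higher number a weaker inhibitor), the higher of the two numbers measured so far. Its nearest neighbour, compound 2 `C[C@H](NC(=O)C(=O)Nc1ccccc1Cc1ccccc1)C(=O)N[C@@H](CC(=O)O)C(=O)COc1c(F)c(F)cc(F)c1F`, gives 10 nM. Compound 3 `C[C@H](NC(=O)C(=O)Nc1cccc2ccccc12)C(=O)N[C@@H](CC(=O)O)C(=O)COc1c(F)c(F)cc(F)c1F` has not yet been measured; it differs from compound 1 by naphthalen-1-yl in place of 2-fluorophenyl on an amide-type nitrogen. Going by the values given here, the one measured step that bears on this change, a 16-fold lower number from compound 1 to compound 2 (1.20 log units; beyond the scatter), was large, and a naphthalen-1-yl is not a benzyl. On that basis a smaller number is expected for compound 3, and the step is estimated as a 4.0-fold lower number from compound 1 to compound 3 (0.60 log units; beyond the scatter). The estimate for compound 3 is therefore 40 nM, with a range from 10 nM to 160 nM.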

Compound 3, half-maximal inhibitory concentration: 86 nM
Beside the measured number, compound 3's estimate is 2.2-fold (0.33 log units) below it; measured number inside the range.
By their numbers in this assay, from the lowest: compound 2; then compounds 3 and 1 (each within the scatter of the next).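

In this assay, naphthalen-1-yl in place of 2-fluorophenyl on the amide-type nitrogen gives a 1.9-fold lower number from compound 1 to compound 3 (0.27 log units; within the scatter). A second six-membered aromatic ring at this position therefore does not by itself bring a step beyond the scatter, whereas the benzyl change gives a 16-fold lower number from compound 1 to compound 2 (1.20 log units; beyond the scatter). No measurement at hand explains why these two changes differ. Still open, going by these compounds, is how a phenoxy group or a longer chain such as phenylethyl, in place of the benzyl of compound 2, would fare in this assay.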